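A few compounds are considered here, and "the series" means these few. Any claim that something is new, unique, unknown or untested is made for them only; others in the source may bear on it.

Measured compounds:
compound 1, `CCS(=O)(=O)Nc1cccc(Cc2c[nH]cn2)c1C`, 1000 nM
compound 2, `CCS(=O)(=O)Nc1cccc2c1CCCC2CN`, < 10000 nM
compound 3, `CCS(=O)(=O)Nc1cccc(NC2=NCCN2)c1`, 355 nM

In an assay on isolated protein for binding affinity to Alpha-1D adrenergic receptor (Rattus norvegicus), read by radioligand binding (on this read-out lower numbers stand for stronger inhibition and higher numbers for weaker inhibition), compound 3 gives 355 nM, the lowest of the two numbers reported. Compound 1 gives 1000 nM, a higher number, and the gap between the two lies beyond the usual scatter. For compound 2 only a limit is reported, < 10000 nM, which is a limit of the assay and not a number; it is described by the limit of < 10000 nM in this assay, at which 1 of the 3 values shown sits.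

Compound 4, `CCS(=O)(=O)Nc1cccc(C2CCNC2)c1`, differs from compound 3 in a single place: a group of 5 heavy atoms (4 carbon, 1 nitrogen; one five-membered non-aromatic ring with 1 hetero atom) in place of a group of 6 heavy atoms (3 carbon, 3 nitrogen; one five-membered non-aromatic ring with 2 hetero atoms), on an aromatic carbon, meta to the (ethylsulfonyl)amino group.

For the measured compounds named here, no measured pair shows this kind of change. Since compound 3 stands at the low end of the numbers and compound 1 and compound 2, with their other groups at this position, give higher numbers or only a limit, the step from compound 3 to compound 4 is expected to go toward a higher number in this assay, beyond the scatter, as a 5.6-fold higher number from compound 3 to compound 4 (0.75 log units; beyond the scatter). Compound 4 is therefore estimated at 2000 nM, with a range from 500 nM to 8000 nM.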

Compound 4, inhibition constant: 1000 nM
Estimate against measurement, compound 4: 2.0-fold (0.30 log units) above; the measured number falls inside the stated range.
By their numbers in this assay, from the lowest: compound 3; then compounds 1 and 4 (each within the scatter of the next).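

In this assay, putting pyrrolidin-3-yl in place of the group of compound 3, on the aromatic carbon meta to the (ethylsulfonyl)amino group, gives a 2.8-fold higher number from compound 3 to compound 4 (0.45 log units; beyond the scatter), and this is the only step shown between compounds that differ in one place. The step is modest, and compound 4 still gives a measured number, 1000 nM, so this position holds a ring with one nitrogen in place of the group with three nitrogens, at the price of a higher number. Nothing reported here speaks to the cause of this step.

The entering group differs from the leaving one in its nitrogen count, its hydrogen-bond donors and acceptors, and its double bond all at once, so a single step cannot show which of these differences carries the change. From the compounds shown here alone, it also remains open how a six-membered piperidine ring, an open-chain amine or a carboxylic acid at this position would read in this assay, and whether any such group would give a number lower than that of compound 3.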